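The source may report more compounds than this note shows. Statements on the series, on what has been measured and on what is new or still open speak of the compounds shown alone.

Measured compounds:
compound 1, `COc1ccc(Cn2cc(CO/N=C/c3c(-c4ccccc4)nc4c(C)cccn34)nn2)cc1`, 100 mg/kg;
compound 2, `COc1ccc(Cn2cc(CO/N=C/c3c(-c4ccc(C)cc4)nc4c(C)cccn34)nn2)cc1`, 100 mg/kg;
compound 3, `Cc1cccn2c(/C=N/O)c(-c3ccc(F)cc3)nc12`, 40 mg/kg.

In a functional assay on the whole organism (strain NMRI) with Mus musculus as the target, with a stated time of 4 h (a lower number here means that less compound is needed, a higher number that more compound is needed for the effect), compound 2 gives 100 mg/kg. It stands level with compound 1 at the digits shown, and these two together have the highest number of the three; compound 3 gives 40 mg/kg, a lower number beyond the scatter. For the measured compounds named here, the only step measured between neighbours, no change at the digits printed from compound 1 to compound 2 (within the scatter), is a methyl in place of hydrogen on an aromatic carbon and left the number unchanged within the scatter.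

Compound 4, `Cc1ccc(-c2nc3c(C)cccn3c2/C=N/OCc2cn(Cc3ccc([N+](=O)[O-])cc3)nn2)cc1`, differs from compound 2 by nitro in place of methoxy on an aromatic carbon. Going by the values given here, no measured step bears on this particular change: the one step recorded touches a different part of the molecule, and compound 3 lacks the whole benzyl-bearing portion, so its value only shows that a smaller compound gave a lower number. Among the compounds with values here, the single recorded step in this assay was flat, and nothing in the data points to either direction for the new group. The expectation is therefore a step of no change at the digits printed from compound 2 to compound 4 (within the scatter), no change beyond the scatter. Compound 4 is estimated to give 100 mg/kg in this assay, with a range of 40 mg/kg to 200 mg/kg.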

Compound 4, minimum effective dose: 20 mg/kg
Compound 4: middle estimate off by 5.0-fold (0.70 log units), on the high side; the measured number lies below the stated range.
By their numbers in this assay, from the lowest: compounds 4 and 3 (each within the scatter of the next); then compounds 1 and 2 (each within the scatter of the next).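

In this assay, the exchange of methoxy for nitro on an aromatic carbon, para to a large group, gave a 5.0-fold lower number from compound 2 to compound 4 (0.70 log units; beyond the scatter). Among the compounds shown, this is the first single-place change that moves the number beyond the scatter; the earlier step, no change at the digits printed from compound 1 to compound 2 (within the scatter), was flat and lay in a different part of the molecule. The 4-methoxybenzyl to 4-nitrobenzyl change thus shows that this position can respond in this whole-animal test, although nothing available here accounts for the size or direction of the step.

The compounds shown leave open whether the lower number goes with the arrival of nitro or simply with the departure of methoxy, and a plain benzyl, a 4-aminobenzyl or a 4-chlorobenzyl at this place would help to separate the two. For the compounds shown here, it also remains open whether the same exchange would give a similar step on the unmethylated phenyl of compound 1, as this single pair is the only reading of the change.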